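The source may report more compounds than this note shows. Statements on the series, on what has been measured and on what is new or still open speak of the compounds shown alone.

Compound 1 `CC(C)(C)OC(=O)NCc1ccccc1NC(=O)c1ccc(-c2ccccc2)cc1` and compound 3 `CC(C)(C)OC(=O)NCc1ccccc1NC(=O)c1cc2cc([N+](=O)[O-])ccc2s1` share much of their structure, but the difference between the two cores is not broken down here. In a physicochemical assay for solubility (a lower number here means a less soluble compound, a higher number a more soluble compound), compound 1 gives < 5 ug/mL, which is a limit of the assay rather than a number. Compound 2 `NC(=O)c1ccccc1NC(=O)c1ccc(-c2ccccc2)cc1` differs from compound 1 by carbamoyl in place of ((tert-butoxycarbonyl)amino)methyl on an aromatic carbon. In this assay compound 2 gives 5 ug/mL. That change made a step of a number no lower from compound 1 to compound 2 (the limit leaves the size open). In this assay compound 3 gives < 5 ug/mL, again a limit and not a number. Compound 4 `NC(=O)c1ccccc1NC(=O)c1cc2cc([N+](=O)[O-])ccc2s1` differs from compound 3 by carbamoyl in place of ((tert-butoxycarbonyl)amino)methyl on an aromatic carbon, the same change as from compound 1 to compound 2, since the two places are described in the same words. Because compound 2 gives 5 ug/mL after this change, and because the limit of < 5 ug/mL in this assay, at which 2 of the 3 values shown sit, shows how little room these measurements leave, compound 4 is expected to give 4 ug/mL, somewhere between 1 ug/mL and 10 ug/mL. The step estimated here is a step that the limit leaves unreadable from compound 3 to compound 4.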

Compound 4, solubility: 10 ug/mL
Compound 4: the middle estimate sits 2.5-fold (0.40 log units) below what was measured; the measured number falls inside the stated range.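

Replacing ((tert-butoxycarbonyl)amino)methyl with carbamoyl on the second core gives a step of an at least 2.0-fold higher number from compound 3 to compound 4 (0.30 log units; that floor lies within the scatter). On the first core, the same change gives a number no lower from compound 1 to compound 2 (the limit leaves the size open), so in these two pairs, the only ones shown, the number does not fall, and the direction of the change carries over from one core to the other as far as the limits allow. These pairs do not show how large the change really is, or whether it is equally large on both cores, because the starting values for compound 1 and compound 3 are limits rather than numbers, so neither step can be read exactly: the limit of < 5 ug/mL in this assay, at which 2 of the 4 values shown sit.

The compounds shown cover only two cores and one swap of groups, so whether the same change holds on a third core remains open. Also open, going by these compounds, is how this assay would respond to a different group on that aromatic carbon, such as an amine or a carboxylic acid.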